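Swapping the aryl group on the imine: a hydroxyphenyl variant

The compounds below may be only part of what the source reports. "The series", "measured", "known", "first", "only" and "open" are said of these compounds alone.

Measured compounds:
compound 1 `COc1ccc(OC)c(/C=N/NC(=O)Nc2ccc(Oc3ccnc(-c4nncn4CCN(C)C)c3)c(F)c2)c1` — 2930 nM
compound 2 `CN(C)CCn1cnnc1-c1cc(Oc2ccc(NC(=O)N/N=C/c3ccccc3)cc2F)ccn1` — 1780 nM
compound 3 `COc1cc(/C=N/NC(=O)Nc2ccc(Oc3ccnc(-c4nncn4CCN(C)C)c3)c(F)c2)cc(OC)c1OC` — 2770 nM

In a functional assay on NCI-H460 cells (Homo sapiens) for cytotoxicity, read by MTT assay, with a stated time of 72 h (on this read-out higher numbers stand for weaker inhibition and lower numbers for stronger inhibition), compound 1 gives 2930 nM. Compound 1 is separated from compound 3 by a 1.1-fold lower number from compound 1 to compound 3 (0.02 log units; within the scatter) and from compound 2 by a 1.6-fold lower number from compound 1 to compound 2 (0.22 log units; within the scatter), so the three measured compounds sit together within the usual scatter, and none can be called stronger or weaker than another. The step from compound 2 to compound 3 is a 1.6-fold higher number from compound 2 to compound 3 (0.19 log units; within the scatter), again within the scatter.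

Compound 4 `CN(C)CCn1cnnc1-c1cc(Oc2ccc(NC(=O)N/N=C/c3ccc(O)cc3)cc2F)ccn1` is not yet measured. It differs from compound 1 as follows: 4-hydroxyphenyl in place of 2,5-dimethoxyphenyl on a carbon with a double bond to nitrogen. Within the data shown here, the steps that bear on this change are the three above, each of which also swaps the aryl group on the carbon with a double bond to nitrogen, and each of which stayed within the scatter. The hydroxyphenyl variant has not been tried, so a step beyond the scatter in this assay is not indicated by these data.

Compound 4 is therefore expected to give about 2300 nM in this assay, with a range from 1000 nM to 5500 nM. The expected step from compound 1 is estimated at a 1.3-fold lower number from compound 1 to compound 4 (0.11 log units; within the scatter).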

Compound 4, half-maximal inhibitory concentration: 1780 nM
For compound 4 the middle estimate is 1.3-fold (0.11 log units) above the measured one, within the range that was stated.
By their numbers in this assay, from the lowest: compounds 2, 4, 3 and 1 (each within the scatter of the next).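

In this assay, 4-hydroxyphenyl brings a hydrogen-bond donor to this place, which 2,5-dimethoxyphenyl lacks, yet the change gives a 1.6-fold lower number from compound 1 to compound 4 (0.22 log units; within the scatter), and the swap from the larger 3,4,5-trimethoxyphenyl gives a 1.6-fold lower number from compound 3 to compound 4 (0.19 log units; within the scatter). The cleanest comparison, hydroxy in place of hydrogen on an aromatic carbon, gives no change at the digits printed from compound 2 to compound 4 (within the scatter), so across these four compounds the aryl group on the carbon with a double bond to nitrogen can carry no substituent, methoxy groups or a hydroxy group with no step beyond the scatter. No measurement here explains this result.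

On these data alone, whether an aminomethyl group or a carboxylic acid on this aryl ring would give a step beyond the scatter remains open. Also open, as far as these compounds go, is whether a simple alkyl chain in place of the aryl group would do so.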